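The source may hold more compounds than are shown below. What is called first, only, known or untested is meant among the compounds shown, and "the series" means these compounds.

Within the data shown here, compound 2 `COc1ccc(C2=NN(C(=O)c3ccc(C)nc3)C(c3ccc(Cl)cc3)C2)cc1` is one of two compounds measured in a functional assay on WM 266-4 cells (Homo sapiens) for antiproliferative activity, read by MTT assay, with a stated time of 24 h; on this read-out lower numbers stand for stronger inhibition of growth and higher numbers for weaker inhibition of growth; in that assay compound 2 gives 890 nM. Among the measured compounds shown here, the only other measured compound is compound 1 `COc1ccc(C2=NN(C(=O)c3ccc(C)nc3Cl)C(c3ccc(Cl)cc3)C2)cc1`, which in this assay gives 1440 nM, and the step of a 1.6-fold lower number from compound 1 to compound 2 (0.21 log units; within the scatter) is the single measured step available. Compound 3 `COc1ccc(C2=NN(C(=O)c3ccc(C)nc3)C(c3ccc(OCc4ccccc4)cc3)C2)cc1` has not yet been measured. It differs from compound 2 by benzyloxy in place of chloro on an aromatic carbon. For the measured compounds named here, none of the measured steps touches the same position or the same kind of group: the step from compound 1 to compound 2 changes a different aromatic carbon and swaps a chloro for hydrogen, not for benzyloxy, so it bears on the new change only in showing that one alteration at the periphery of the shared core stayed within the scatter. Going by the values given here, with no direct precedent, the expectation for compound 3 in this assay is a step of about a 1.0-fold higher number from compound 2 to compound 3 (0.00 log units; within the scatter), that is, no change beyond the scatter, with a wide range to reflect the lack of data. Compound 3 is therefore estimated at 900 nM, expected between 250 nM and 3500 nM.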

Compound 3, concentration for 50% growth inhibition: 7950 nM
The estimate for compound 3 lay 8.8-fold (0.95 log units) below the measured number, and the stated range ends below it.
By their numbers in this assay, from the lowest: compounds 2 and 1 (each within the scatter of the next); then compound 3.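

In this assay, among these compounds, benzyloxy in place of chloro on an aromatic carbon para to a large group gives an 8.9-fold higher number from compound 2 to compound 3 (0.95 log units; beyond the scatter), the first step in this small set to lie beyond the scatter, whereas a 1.6-fold lower number from compound 1 to compound 2 (0.21 log units; within the scatter), at a different aromatic carbon, stayed within it. This shows that the position para to a large group is sensitive to at least this replacement, with growth inhibition weaker once chloro gives way to benzyloxy, which brings in a six-membered aromatic ring of carbon only and a hydrogen-bond acceptor. No measurement at hand explains why this change weakens the read-out.

The compounds shown carry only chloro and benzyloxy at this carbon, so they cannot separate any contribution of the oxygen from that of the added ring, or show whether chloro itself contributes anything. Hydrogen, methoxy, phenyl or an amine at the same carbon would help to divide these possibilities and show whether the weaker inhibition belongs to benzyloxy alone or extends to other replacements.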